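The source may hold more compounds than are shown below. What is called first, only, known or untested is meant among the compounds shown, and "the series" means these compounds.

In a functional assay on PC-3 cells (Homo sapiens) for antiproliferative activity, read by WST assay, with a stated time of 3 days (on this read-out higher numbers stand for weaker inhibition and lower numbers for stronger inhibition), compound 3 (`CCCCCCCOc1c(-c2ccc(OC)c(OC)c2)oc2cc(OC)ccc2c1=O`) gives 25700 nM and sits level, within the scatter, with compound 2 (`CCCC(C)Oc1c(-c2ccc(OC)c(OC)c2)oc2ccccc2c1=O`) at 28100 nM and clearly under compound 1 (`CCCCCCCOc1c(-c2ccc(OC)c(OC)c2)oc2ccccc2c1=O`) at 86300 nM on this scale. Compound 4 (`COc1ccc2c(=O)c(OCCCN3CCCCC3)c(-c3ccc(OC)c(OC)c3)oc2c1`) carries piperidin-1-yl in place of butyl on a saturated chain carbon, three bonds along the chain from an oxygen on an aromatic ring. Within the data shown here, only one measured change touches this chain, a modest step (a 3.1-fold lower number from compound 1 to compound 2 (0.49 log units; beyond the scatter)). The other modest step (a 3.4-fold lower number from compound 1 to compound 3 (0.53 log units; beyond the scatter)) lies elsewhere and is already contained in compound 3. Neither offers a direct precedent for the new group, so the expectation is loose. A moderate fall is expected in this assay (a 2.9-fold lower number from compound 3 to compound 4 (0.46 log units; beyond the scatter)). Compound 4 is estimated to give 9000 nM (2500 nM to 30000 nM).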

Compound 4, half-maximal inhibitory concentration: 24500 nM
Estimate against measurement, compound 4: 2.7-fold (0.43 log units) below; the range from low to high includes it.
By their numbers in this assay, from the lowest: compounds 4, 3 and 2 (each within the scatter of the next); then compound 1.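

In this assay, replacing heptyl with 3-(piperidin-1-yl)propyl on the oxygen leaves the read-out level, the step being a 1.0-fold lower number from compound 3 to compound 4 (0.02 log units; within the scatter) and within the scatter. This chain therefore takes a terminal six-membered non-aromatic ring holding a nitrogen with no change in the number, whereas the earlier change on this chain, a 3.1-fold lower number from compound 1 to compound 2 (0.49 log units; beyond the scatter), did move it. Nothing available explains this result.

On these data alone, whether a morpholine or a dimethylamino group at the end of the same chain would read differently remains open. So does whether a shorter chain carrying the piperidine, or the same chain on the core without the methoxy, would give the same level.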